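This account rests on a few compounds, and the source may have more. Where it says the series, first, only, none or still open, it means among the compounds named here.

Compound 1: `C[n+]1ccn(CCCC(C)(C)[N+](=O)[O-])c1/C=N/O`, -2.18 in a physicochemical assay for lipophilicity; a lower number here means a more polar compound, a higher number a more lipophilic compound
Compound 2: `CC[n+]1ccn(CCCC(C)(C)[N+](=O)[O-])c1/C=N/O`, -1.8 in this assay
Compound 3: `CCS(=O)(=O)CCOCn1cc[n+](C)c1/C=N/O`, < -2.7 in this assay

Compound 1 and compound 2 share a core and differ in one place: methyl in place of hydrogen on a saturated chain carbon bound to an aromatic nitrogen. In this assay compound 1 gives -2.18. Compound 2, carrying the methyl, gives -1.8. The step is a number 0.38 log units higher from compound 1 to compound 2 (beyond the scatter), so the added methyl moved the number upward, and by more than repeated measurements of this kind would wander on their own.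

Compound 3 has a different core from compound 1, and the difference between the two cores is not broken down here. In this assay compound 3 gives < -2.7, which is a limit of the assay rather than a number. This value is the limit of < -2.7 in this assay, at which 1 of the 3 values shown sits.

Compound 4, `CC[n+]1ccn(COCCS(=O)(=O)CC)c1/C=N/O`, is not yet measured. It stands to compound 3 exactly as compound 2 stands to compound 1: methyl in place of hydrogen on a saturated chain carbon bound to an aromatic nitrogen. The place is the same in both pairs, a saturated chain carbon bound to an aromatic nitrogen. If the change behaves as it did between compound 1 and compound 2, compound 4 is expected to sit higher than compound 3 by a step of about a number at least 0.25 log units higher from compound 3 to compound 4 (that floor lies within the scatter), resting on the measured step of a number 0.38 log units higher from compound 1 to compound 2 (beyond the scatter). Because compound 3 gives only the limit < -2.7, the starting point is uncertain, and compound 4 may also fall at the limit. Compound 4 is estimated at -2.45, most likely between -3 and -2.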

Compound 4, distribution coefficient: -2.67
Compound 4: middle estimate off by 0.22 log units, on the high side; the range from low to high includes it.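

In this assay, within the data shown here, the same change, methyl in place of hydrogen on a saturated chain carbon bound to an aromatic nitrogen, gives a number 0.38 log units higher from compound 1 to compound 2 (beyond the scatter) on the first core and a number at least 0.03 log units higher from compound 3 to compound 4 (that floor lies within the scatter) on the second. This shows that the second pair does not go against the first: the printed floor is compatible with a step as large as the one first measured, but it is equally compatible with a step too small to tell from the ordinary wander of repeated measurements. It does not show that the change carries over with the same size, or even clearly carries over at all, because the second step starts from a limit of the assay and not from a number: the limit of < -2.7 in this assay, at which 1 of the 4 values shown sits.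

With only two pairs, the compounds shown leave open whether the step would hold on any further core. They also leave open whether a longer chain such as propyl in place of the ethyl would move the number further on either core, and what a chain ending in an amine or a carboxylic acid would do at that same place.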